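Swapping Ethyl for Trifluoromethyl on a Shared Core

This account rests on a few compounds, and the source may have more. Where it says the series, first, only, none or still open, it means among the compounds named here.

Values measured in a functional assay on aorta (Rattus norvegicus, strain Wistar), in the presence of a further agent that is not named here; on this read-out lower numbers stand for smaller maximal responses and higher numbers for larger maximal responses:
- compound 1, `Cc1ccc2c(c1)N(C1=CCCC1=O)CC(C)(C)S2`, gives 78%
- compound 2, `CCc1ccc2c(c1)N(C1=CCCC1=O)CC(C)(C)S2`, gives 69%

Compound 2 holds the lower of the two numbers, and the step of a number 9 percentage points lower from compound 1 to compound 2 (within the scatter) stays within the scatter, so compound 1 and compound 2 cannot be told apart on this read-out.

Compound 3, `CC1(C)CN(C2=CCCC2=O)c2cc(C(F)(F)F)ccc2S1`, has not been measured yet. It differs from compound 2 in one place: trifluoromethyl in place of ethyl on an aromatic carbon. Among the compounds with values here, no measured step involves a trifluoromethyl group. Within the data shown here, the only measured step, a number 9 percentage points lower from compound 1 to compound 2 (within the scatter), exchanges groups at the same aromatic carbon and did not move the read-out beyond the scatter, which is the sole guide available here; it does not show that the new group must behave the same way.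

With this single, flat step as the only reference, compound 3 is expected to stay close to compound 2, an estimated a number 1 percentage points higher from compound 2 to compound 3 (within the scatter) in this assay . The estimate for compound 3 is 70%, with a range from 50% to 90%.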

Compound 3, largest response reached (Emax), in percent of the reference or control that the assay uses: 96%
Estimate against measurement, compound 3: 26 percentage points below, and the stated range ends below it.
By their numbers in this assay, from the lowest: compounds 2 and 1 (each within the scatter of the next); then compound 3.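

In this assay, trifluoromethyl in place of ethyl gives a number 27 percentage points higher from compound 2 to compound 3 (beyond the scatter), and trifluoromethyl in place of methyl gives a number 18 percentage points higher from compound 1 to compound 3 (beyond the scatter). This aromatic carbon therefore does not tolerate every exchange without consequence: it looked unresponsive when only methyl and ethyl could be compared, yet compound 3 now stands clear of both compounds, while those two remain within the scatter of each other. Nothing available explains why trifluoromethyl separates from the two other groups in this way.

With only one group of this kind in the set, it remains open whether the higher number belongs to trifluoromethyl alone or would also appear with a chlorine atom, a methoxy group or a nitrile on the same carbon. On these data alone, it also remains open whether a longer chain such as propyl would stay close to methyl and ethyl, and whether the same exchange would have a similar effect on the shared core at its other aromatic carbons.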